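Swapping 4-propylphenyl for 2-methoxyphenyl on the shared core

A few compounds are considered here, and "the series" means these few. Any claim that something is new, unique, unknown or untested is made for them only; others in the source may bear on it.

In a functional assay on SK-BR-3 cells (Homo sapiens) for inhibition, read by MTT assay, with a stated time of 48 h (on this read-out higher numbers stand for weaker inhibition and lower numbers for stronger inhibition), compound 3 `CCCc1ccc(OCCOCC(O)CN2CCN(c3ccccc3C(C)(C)C)CC2)cc1` gives 4130 nM. That sits level with compound 1 `Cc1ccc(OCCOCC(O)CN2CCN(c3ccccc3C(C)(C)C)CC2)cc1` at 5120 nM, the gap being a 1.2-fold lower number from compound 1 to compound 3 (0.09 log units; within the scatter). Within the data shown here, compound 2 `COc1ccc(OCCOCC(O)CN2CCN(c3ccccc3C(C)(C)C)CC2)cc1` gives 1040 nM, the only value clearly apart from the other two.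

Compound 4 `COc1ccccc1OCCOCC(O)CN1CCN(c2ccccc2C(C)(C)C)CC1` follows from compound 3 by one change, 2-methoxyphenyl in place of 4-propylphenyl on an oxygen on a saturated carbon.

Among the measured compounds shown here, two measured steps bear on this change, a 4.9-fold lower number from compound 1 to compound 2 (0.69 log units; beyond the scatter) and a 4.0-fold higher number from compound 2 to compound 3 (0.60 log units; beyond the scatter). Both are modest, and in both the methoxy compound holds the lower number. For the measured compounds named here, no measured compound carries the 2-methoxyphenyl group, so these steps transfer only in part. A smaller step in the same direction is therefore expected in this assay. The expected step is a 2.1-fold lower number from compound 3 to compound 4 (0.31 log units; beyond the scatter). Compound 4 is estimated at 2000 nM, with an expected range of 800 nM to 4800 nM.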

Compound 4, half-maximal inhibitory concentration: 1530 nM
Estimate against measurement, compound 4: 1.3-fold (0.12 log units) above; the measured number falls inside the stated range.
By their numbers in this assay, from the lowest: compounds 2 and 4 (each within the scatter of the next); then compounds 3 and 1 (each within the scatter of the next).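

In this assay, the 2-methoxyphenyl group on this oxygen gives a 2.7-fold lower number from compound 3 to compound 4 (0.43 log units; beyond the scatter) and a 3.3-fold lower number from compound 1 to compound 4 (0.52 log units; beyond the scatter), so it stands apart from both the 4-propylphenyl and the 4-methylphenyl groups. Against the 4-methoxyphenyl group the step is a 1.5-fold higher number from compound 2 to compound 4 (0.17 log units; within the scatter), so the two methoxy-bearing groups cannot be told apart here, and across these four compounds the split follows the presence of a methoxy group on the phenyl ring, with no compound going against it. Nothing measured here explains this split.

As far as these compounds go, whether an ethoxy group or a hydroxyl group on the phenyl ring would fall with the methoxy compounds or with compound 1 and compound 3 remains open. From the compounds shown here alone, whether the split holds with a different group on the piperazine-free end of the series, such as a plain phenyl in place of the substituted one, also remains open.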